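From Aryl Amide to Primary Amide on a Shared Core

This account rests on a few compounds, and the source may have more. Where it says the series, first, only, none or still open, it means among the compounds named here.

Three measured compounds share one core and differ only in what the carbonyl carbon carries. Compound 1 `CCOC(=O)C(=Cc1c(-c2ccccc2)[nH]c2ccccc12)C(=O)OCC` bears two ethyl esters, compound 2 `N#C/C(=C\c1c(-c2ccccc2)[nH]c2ccccc12)C(=O)N1CCCCC1` a nitrile together with a piperidin-1-yl amide, and compound 3 `N#C/C(=C\c1c(-c2ccccc2)[nH]c2ccccc12)C(=O)Nc1ccc(Cl)cc1` a nitrile together with a (4-chlorophenyl)amino amide. In a functional assay on MT4 cells (Homo sapiens) for antiproliferative activity, read by MTT assay, with a stated time of 96 h (on this read-out lower numbers stand for an effect already at smaller amounts and higher numbers for an effect only at larger amounts of compound), compound 1 gives 2300 nM, compound 2 gives 9600 nM, and compound 3 gives 1700 nM. Compound 3 stands at the lowest of these three numbers, though its gap to compound 1 lies within the scatter, whereas the step of a 5.6-fold lower number from compound 2 to compound 3 (0.75 log units; beyond the scatter) lies beyond it.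

Compound 4 `N#C/C(=C\c1c(-c2ccccc2)[nH]c2ccccc12)C(N)=O` is the member not yet measured, and it differs from compound 3 by a single change: hydrogen in place of 4-chlorophenyl on an amide-type nitrogen. Going by the values given here, only one measured step touches this position, a 5.6-fold lower number from compound 2 to compound 3 (0.75 log units; beyond the scatter), and it shows the number falling well beyond the scatter when the aryl group entered on the amide nitrogen. Among the compounds with values here, no measured compound carries a bare amide nitrogen, so the new case has no direct mirror. On that basis the step of a 3.5-fold higher number from compound 3 to compound 4 (0.55 log units; beyond the scatter) is estimated to run toward a higher number, since compound 4 gives up the aryl group. Compound 4 is therefore expected to give 6000 nM, with a range from 2000 nM to 20000 nM.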

Compound 4, half-maximal effective concentration: 6000 nM
Compound 4: the middle estimate sits on the measured number at the digits printed; the range from low to high includes it.
By their numbers in this assay, from the lowest: compounds 3 and 1 (each within the scatter of the next); then compounds 4 and 2 (each within the scatter of the next).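

Compound 4 separates what the earlier step could not: that step changed piperidin-1-yl into (4-chlorophenyl)amino, so it could not show what the 4-chlorophenyl group does on the amide-type nitrogen by itself. In this assay, the step of a 3.5-fold higher number from compound 3 to compound 4 (0.55 log units; beyond the scatter) isolates that group, and taking it away for hydrogen leaves a change beyond the scatter. The step of a 1.6-fold lower number from compound 2 to compound 4 (0.20 log units; within the scatter) stays within the scatter, so amino and piperidin-1-yl on the carbonyl carbon cannot be told apart here, and among these three nitrile amides only compound 3 stands apart, with both of its steps beyond the scatter.

As far as these compounds go, what a plain phenyl, a benzyl group or a methyl group would give on this nitrogen stays open, and so does whether the chlorine or the aromatic ring carries the step. From the compounds shown here alone, it is also open whether a carboxylic acid in place of the nitrile would leave this order of the amides unchanged. Nothing given here accounts for the difference that the 4-chlorophenyl group makes.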